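This account rests on a few compounds, and the source may have more. Where it says the series, first, only, none or still open, it means among the compounds named here.

In a functional assay on RS4-11 cells (Homo sapiens) for inhibition, read by CCK-8 assay, with a stated time of 48 h, tested at 20 uM (on this read-out higher numbers stand for more inhibition of growth at the one concentration tested and lower numbers for less inhibition of growth), compound 1 `N#C/C(=C\c1ccccc1OS(=O)(=O)c1ccc([N+](=O)[O-])cc1)C(=O)Nc1nnc(-c2cccs2)s1` gives 40% and compound 2 `N#C/C(=C\c1ccccc1OS(=O)(=O)c1ccc([N+](=O)[O-])cc1)C(=O)Nc1nnc(Cc2cccc3ccccc23)s1` gives 58% while compound 3 `N#C/C(=C\c1ccccc1OS(=O)(=O)c1ccc([N+](=O)[O-])cc1)C(=O)Nc1nnc(Cc2ccccc2)s1` gives 57% on the same read-out. Compound 3 thus stands within the scatter of compound 2 and beyond the scatter over compound 1. The next step leads to compound 4 `N#C/C(=C\c1ccccc1OS(=O)(=O)c1ccc([N+](=O)[O-])cc1)C(=O)Nc1nnc(Cc2ccc(F)cc2)s1` by the change fluoro in place of hydrogen on an aromatic carbon with fluoro in place of hydrogen on an aromatic carbon, para to a large group, so that benzyl becomes 4-fluorobenzyl. For the measured compounds named here, no measured step is this exchange itself. The closest is a number 1 percentage points lower from compound 2 to compound 3 (within the scatter) where phenyl replaces naphthalen-1-yl on the same saturated chain carbon. Replacing thiophen-2-yl gave the modest steps of a number 17 percentage points higher from compound 1 to compound 3 (beyond the scatter) and a number 18 percentage points higher from compound 1 to compound 2 (beyond the scatter) but that exchange swaps a whole group and says little about a single fluoro. Given a number 1 percentage points lower from compound 2 to compound 3 (within the scatter) no step beyond the scatter is expected in this assay for this exchange. The estimated change is a number 1 percentage points higher from compound 3 to compound 4 (within the scatter) and so lies within the scatter. Compound 4 is expected at 58% in this assay with an estimated range from 46% to 69% for repeat measurements.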

Compound 4, percent growth inhibition at one concentration: 55%
Beside the measured number, compound 4's estimate is 3 percentage points above it; measured number inside the range.
By their numbers in this assay, from the lowest: compound 1; then compounds 4, 3 and 2 (each within the scatter of the next).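

In this assay, the exchange of hydrogen for fluoro on an aromatic carbon, para to a large group, can now be read directly: it leaves the number within the scatter (a number 2 percentage points lower from compound 3 to compound 4 (within the scatter)). 4-Fluorobenzyl also stays level with (naphthalen-1-yl)methyl (a number 3 percentage points lower from compound 2 to compound 4 (within the scatter)) and keeps a modest margin over thiophen-2-yl (a number 15 percentage points higher from compound 1 to compound 4 (beyond the scatter)), so compounds 2, 3 and 4 form one level, with compound 1 under it. Nothing measured here accounts for these numbers.

As far as these compounds go, whether a methoxy, an amine or a carboxylic acid at this same place would move the number beyond the scatter remains open. Also open, from the compounds shown here alone, is how a longer chain between the core and the ring would read, and since each compound has a reading at only one concentration, potency differences within this level cannot be resolved.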